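The source may hold more compounds than are shown below. What is called first, only, known or untested is meant among the compounds shown, and "the series" means these compounds.

Measured compounds in a functional assay on HL-60 cells (Homo sapiens) for cytotoxicity, read by MTT assay, with a stated time of 72 h; a higher number here means a weaker inhibitor, a lower number a stronger inhibitor:
- compound 1 `COc1ccc(S(=O)(=O)c2nc3ccccc3nc2Nc2ccccc2)cc1`: 260 nM
- compound 2 `COc1ccc(Nc2nc3ccccc3nc2S(=O)(=O)c2ccc(OC)cc2)cc1`: 1190 nM

Compound 2 gives the higher of the two numbers in this assay; its nearest neighbour is compound 1, and the step of a 4.6-fold higher number from compound 1 to compound 2 (0.66 log units; beyond the scatter) lies beyond the scatter, so compound 2 reads as the weaker of the two measured compounds.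

Compound 3 `COc1ccc(S(=O)(=O)c2nc3ccccc3nc2Nc2cc(OC)cc(OC)c2)cc1` is not yet measured. It differs from compound 2 by 3,5-dimethoxyphenyl in place of 4-methoxyphenyl on a nitrogen on an aromatic ring.

Going by the values given here, only one measured step bears on this change, and only indirectly: a 4.6-fold higher number from compound 1 to compound 2 (0.66 log units; beyond the scatter) shows that a single methoxy added on that aryl group moved the number up by a modest amount. The change to compound 3 is not the same kind of step, since one methoxy leaves and two enter at other positions of the same ring. Among the compounds with values here, there is no measured pair that isolates such a rearrangement, so the direction is open. The working expectation is a step of a 1.3-fold higher number from compound 2 to compound 3 (0.10 log units; within the scatter) that stays within the scatter of the number for compound 2, with wide uncertainty. Compound 3 is therefore estimated at 1500 nM, with a range from 400 nM to 6000 nM.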

Compound 3, half-maximal inhibitory concentration: 1710 nM
Compound 3: the middle estimate sits 1.1-fold (0.06 log units) below what was measured, within the range that was stated.
By their numbers in this assay, from the lowest: compound 1; then compounds 2 and 3 (each within the scatter of the next).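

In this assay, 3,5-dimethoxyphenyl in place of 4-methoxyphenyl on a nitrogen on an aromatic ring gives a 1.4-fold higher number from compound 2 to compound 3 (0.16 log units; within the scatter), so the two substituted aryl groups cannot be told apart at this position, even though the entering group carries one more methoxy. Against the plain phenyl of compound 1, the same position gives a 6.6-fold higher number from compound 1 to compound 3 (0.82 log units; beyond the scatter), so both methoxy-bearing aryl groups shown now stand apart from phenyl, beyond the scatter, and this holds for two different methoxy patterns rather than one. No available evidence accounts for these numbers.

The compounds shown carry only phenyl and methoxy-bearing phenyl groups on this nitrogen, so it stays open whether a different substituent on that ring, such as a fluorine, a hydroxyl or a dimethylamino group, would keep the number near that of compound 1 or carry it further away. Also open, as far as these compounds go, is whether this reading holds for changes elsewhere on the shared core, since all three compounds differ only in the aryl group on this nitrogen.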